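This account rests on a few compounds, and the source may have more. Where it says the series, first, only, none or still open, it means among the compounds named here.

Measured compounds:
- compound 1 `N#Cc1cccc(OC(=O)N2CCC(S(=O)(=O)C(c3ccccc3)c3ccccc3)CC2)c1`, 1000 nM
- compound 2 `N#Cc1cc(O)cc(OC(=O)N2CCC(C(c3ccccc3)c3ccccc3)CC2)c1`, 98.2 nM

Compound 2 has the lowest number of the two in an assay on isolated protein for inhibition of Monoglyceride lipase (Rattus norvegicus), read by fluorescence, with stated times of 15 min and 3 h; on this read-out lower numbers stand for stronger inhibition and higher numbers for weaker inhibition; compound 1 gives 1000 nM, a higher number that lies beyond the usual scatter, though the two structures differ in more than one place, so no single change can be read from that gap.

Compound 3 `N#Cc1cccc(OC(=O)N2CCC(C(c3ccccc3)c3ccccc3)CC2)c1` has not yet been measured. It differs from compound 2 in one place: hydrogen in place of hydroxy on an aromatic carbon. Going by the values given here, no measured pair shows this change alone, so its effect is not known from the numbers at hand. A step of modest size, toward a higher number in this assay, is expected here; it may still fall within the scatter. Compound 3 is therefore estimated at 200 nM, within 50 nM to 1000 nM, an expected step of a 2.0-fold higher number from compound 2 to compound 3 (0.31 log units; beyond the scatter).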

Compound 3, half-maximal inhibitory concentration: 36.5 nM
Compound 3: the middle estimate sits 5.5-fold (0.74 log units) above what was measured, outside the stated range (below it).
By their numbers in this assay, from the lowest: compound 3; then compound 2; then compound 1.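

In this assay, going by these compounds alone, the pair of compound 2 and compound 3 is the first to isolate a single change, and replacing 3-cyano-5-hydroxyphenyl with 3-cyanophenyl gives a 2.7-fold lower number from compound 2 to compound 3 (0.43 log units; beyond the scatter) as a modest step beyond the usual scatter. The hydroxy on this aromatic carbon is therefore not required for inhibition, and in this one pair the ring carrying hydrogen there gives the lower number. No measurement at hand accounts for the direction of this step.

Still open, from the compounds shown here alone, is whether another group on this aromatic carbon, such as an amine or a methoxy group, would give a lower or a higher number than hydrogen does. Going by these compounds, it is also open whether the same swap of hydroxy for hydrogen would move the number the same way on the core of compound 1.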